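The source may hold more compounds than are shown below. What is called first, only, known or untested is meant among the compounds shown, and "the series" means these compounds.

Compound 1: `O=C(Nc1ccc(Oc2ccnc3[nH]ccc23)cc1)c1nn(-c2ccc(Br)cc2)ccc1=O` — 7890 nM
Compound 2: `Cn1ccc2c(Oc3ccc(NC(=O)c4nn(-c5ccc(Br)cc5)ccc4=O)cc3)ccnc21` — 16300 nM

In a functional assay on MCF7 cells (Homo sapiens) for cytotoxicity, read by MTT assay, with a stated time of 72 h (on this read-out lower numbers stand for stronger inhibition and higher numbers for weaker inhibition), compound 2 gives the higher of the two numbers, the weaker inhibition. Going by the values given here, the only recorded step is a 2.1-fold higher number from compound 1 to compound 2 (0.32 log units; beyond the scatter), a methyl placed on a ring nitrogen, and it says nothing about the aryl ring that changes next. Compound 3 `Cn1ccc2c(Oc3ccc(NC(=O)c4nn(-c5ccc(Cl)c(F)c5)ccc4=O)cc3)ccnc21` differs from compound 2 by 4-chloro-3-fluorophenyl in place of 4-bromophenyl on an aromatic nitrogen. Among the compounds with values here, no measured step bears on this swap, so the expected step is a 1.1-fold lower number from compound 2 to compound 3 (0.04 log units; within the scatter), within the scatter. Compound 3 is estimated at 15000 nM, with a range from 6000 nM to 40000 nM.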

Compound 3, half-maximal inhibitory concentration: 16800 nM
The estimate for compound 3 lay 1.1-fold (0.05 log units) below the measured number, within the range that was stated.
By their numbers in this assay, from the lowest: compound 1; then compounds 2 and 3 (each within the scatter of the next).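

In this assay putting 4-chloro-3-fluorophenyl in place of 4-bromophenyl gives a 1.0-fold higher number from compound 2 to compound 3 (0.01 log units; within the scatter) and so shows that this position tolerates this exchange of one halogenated phenyl ring for another with no readable change. The earlier step involved only a methyl and could not show this. No measured evidence explains why the two rings read alike. Still open, on these data alone, is whether a phenyl ring carrying an amine or a carboxylic acid would read differently here. Also open, as far as these compounds go, is whether the same swap reads alike on the core of compound 1.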